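This account rests on a few compounds, and the source may have more. Where it says the series, first, only, none or still open, it means among the compounds named here.

Compound 1 `Cc1cccc(Nc2nc(-c3ccncc3-c3ccc(S(C)(=O)=O)cc3)cs2)c1` and compound 2 `CC(C)c1cccc(Nc2nc(-c3ccncc3)cs2)c1` share a core. In a functional assay on RCC4 cells (Homo sapiens) for inhibition, read by XTT assay, with a stated time of 4 days (a lower number here means a stronger inhibitor, a higher number a weaker inhibitor), compound 1 gives 1600 nM; 1620 nM (2 entries), while compound 2 gives 17400 nM, the higher of the two numbers, so compound 2 is the weaker inhibitor of the pair. Compound 3 `CC(C)(C)c1cccc(Nc2nc(-c3ccncc3)cs2)c1` differs from compound 2 by methyl in place of hydrogen on a saturated chain carbon bound to an aromatic carbon and two saturated chain carbons. No measured step of this kind exists among these compounds, so the expected step of a 1.0-fold higher number from compound 2 to compound 3 (0.01 log units; within the scatter) is small, likely within the usual scatter, in either direction. Compound 3 is therefore estimated at 18000 nM in this assay, with a range from 7000 nM to 45000 nM.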

Compound 3, half-maximal inhibitory concentration: 60300 nM
For compound 3 the middle estimate is 3.4-fold (0.53 log units) below the measured one; the whole stated range lies below it.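

In this assay, this saturated chain carbon proves sensitive to a very small edit: changing isopropyl to tert-butyl gives a 3.5-fold higher number from compound 2 to compound 3 (0.54 log units; beyond the scatter), so the added methyl goes with weaker inhibition. One carbon atom is enough to move the number here. The step is also much wider than the gap between repeat readings in this assay: the several entries of compound 1 in this assay, 1600 nM; 1620 nM (2 entries).

These compounds cannot say why the added methyl weakens inhibition. Going by these compounds, it also remains open how a cyclopropyl group or a hydroxyl group in place of this methyl would read, and whether the same step would appear on the core of compound 1.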